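Hydroxymethyl to Cyano on the Pendant Phenyl Ring

The compounds below may be only part of what the source reports. "The series", "measured", "known", "first", "only" and "open" are said of these compounds alone.

Measured so far:
compound 1, `O=C1C=CC2(C=C1)OC(=O)C(c1cc3ccccc3o1)=C2c1ccccc1`: 5800 nM
compound 2, `O=C1C=CC2(C=C1)OC(=O)C(c1ccc(CO)cc1)=C2c1ccccc1`: 5760 nM

In a functional assay on MCF7 cells (Homo sapiens) for antiproliferative activity, read by MTT assay, with a stated time of 48 h (on this read-out higher numbers stand for weaker inhibition and lower numbers for stronger inhibition), compound 2 gives 5760 nM, the lowest of the two numbers shown, though the one measured step, a 1.0-fold lower number from compound 1 to compound 2 (0.00 log units; within the scatter), is within the scatter. Compound 3, `N#Cc1ccc(C2=C(c3ccccc3)C3(C=CC(=O)C=C3)OC2=O)cc1`, is unmeasured; it differs from compound 2 by cyano in place of hydroxymethyl on an aromatic carbon. For the measured compounds named here, no measured step touches this change, and the one step known is within the scatter, giving no lead. For compound 3 the expected step is a 1.2-fold lower number from compound 2 to compound 3 (0.06 log units; within the scatter), nothing beyond the scatter. Compound 3 is therefore estimated at 5000 nM, with a range from 1800 nM to 15000 nM.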

Compound 3, half-maximal inhibitory concentration: 19000 nM
The estimate for compound 3 lay 3.8-fold (0.58 log units) below the measured number; the measured number lies above the stated range.
By their numbers in this assay, from the lowest: compounds 2 and 1 (each within the scatter of the next); then compound 3.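

In this assay, the group on this phenyl ring now moves the number: cyano in place of hydroxymethyl, para to a large group, gives a 3.3-fold higher number from compound 2 to compound 3 (0.52 log units; beyond the scatter) and so ends the flat picture of the earlier pair. Swapping 1-benzofuran-2-yl for 4-cyanophenyl gives a 3.3-fold higher number from compound 1 to compound 3 (0.52 log units; beyond the scatter) and so sets compound 3 apart from both earlier compounds. Nothing available explains this rise.

Still open, on these data alone, is whether an amine or a carboxylic acid on this aromatic carbon would fall with compound 2 or with compound 3. As far as these compounds go, whether a longer chain ending in hydroxyl would do the same also remains unknown.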